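Working notes: methyl for hydrogen at two places in a small series

The compounds below may be only part of what the source reports. "The series", "measured", "known", "first", "only" and "open" are said of these compounds alone.

Measured so far, in a functional assay on the whole organism for inhibition, with Rattus norvegicus as the target; on this read-out higher numbers stand for an effect only at larger amounts of compound and lower numbers for an effect already at smaller amounts:
compound 1 `CC(C)c1ccc(OC(Cc2ccccc2)C(=O)O)cc1` gives 50 mg/kg
compound 2 `CC(C)c1ccc(OC(Cc2ccc(Cl)cc2)C(=O)O)cc1` gives 10 mg/kg
compound 3 `CC(C)(C)c1ccc(OC(Cc2ccc(Cl)cc2)C(=O)O)cc1` gives 25 mg/kg

Compound 1 and compound 2 differ in their cores by hydrogen in place of chloro on an aromatic carbon; that difference gives a 5.0-fold lower number from compound 1 to compound 2 (0.70 log units; beyond the scatter). Within the core of compound 2, the change methyl in place of hydrogen on a saturated chain carbon bound to an aromatic carbon and two saturated chain carbons gives a 2.5-fold higher number from compound 2 to compound 3 (0.40 log units; beyond the scatter).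

Compound 4 `CC(C)c1ccc(OC(C)(Cc2ccccc2)C(=O)O)cc1` differs from compound 1 by methyl in place of hydrogen on a saturated chain carbon bound to a carbonyl carbon, an oxygen on an aromatic ring and a saturated chain carbon. This is the same kind of change as from compound 2 to compound 3, but not the same: there the carbon bearing the new methyl is bound to an aromatic carbon and two saturated chain carbons, here to a carbonyl carbon, an oxygen on an aromatic ring and a saturated chain carbon. Going by the values given here, only one such step is measured, at the other place. Beside it, a step of a 1.6-fold higher number from compound 1 to compound 4 (0.20 log units; within the scatter) is expected for compound 4, resting on a 2.5-fold higher number from compound 2 to compound 3 (0.40 log units; beyond the scatter) and the value of compound 1, 50 mg/kg, with wide uncertainty. Compound 4 is thus estimated at 80 mg/kg in this assay, expected between 25 mg/kg and 250 mg/kg.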

Compound 4, dose for half-maximal effect: > 10 mg/kg
Compound 4 gave a limit, no number (the forecaster's own chance of this, stated with the estimate: 15%); the middle value does not contradict the limit.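

In this assay compound 4 gives > 10 mg/kg, a limit and not a number, so the step from compound 1 to compound 4 cannot be read. The compounds shown leave open whether methyl in place of hydrogen at this carbon changes the number, and in which direction.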